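A few compounds are considered here, and "the series" means these few. Any claim that something is new, unique, unknown or untested is made for them only; others in the source may bear on it.

Compound 1, `C=C(Br)C(=O)Nc1ccc(/C=C/C(=O)c2ccccc2)cc1`, is the simplest member of this set; in a functional assay on L1210 cells (Mus musculus) for antiproliferative activity, with a stated time of 48 h (a lower number here means a stronger inhibitor, a higher number a weaker inhibitor), compound 1 gives 5000 nM. Compound 2, `C=C(Br)C(=O)Nc1ccc(/C=C/C(=O)c2ccc(OC)cc2)cc1`, carries a methoxy in place of hydrogen on an aromatic carbon, and in this assay compound 2 gives 980 nM, so that the change gave a 5.1-fold lower number from compound 1 to compound 2 (0.71 log units; beyond the scatter). Compound 3, `C=C(Br)C(=O)Nc1ccc(C(=O)/C=C/c2cccc(OC)c2)cc1`, rests on a different core; how the two cores differ is not broken down here. In this assay compound 3 gives 1100 nM. Compound 4, `C=C(Br)C(=O)Nc1ccc(C(=O)/C=C/c2cc(OC)cc(OC)c2)cc1`, is still to be measured; it differs from compound 3 by methoxy in place of hydrogen on an aromatic carbon. This is the same kind of change as that from compound 1 to compound 2, but not the same: in compound 2 the methoxy sits para to a large group, whereas in compound 4 it sits meta to a large group and meta to a methoxy group. Because the earlier step was a 5.1-fold lower number from compound 1 to compound 2 (0.71 log units; beyond the scatter), compound 4 is expected to give a lower number than compound 3, though a smaller step is expected, a 1.6-fold lower number from compound 3 to compound 4 (0.20 log units; within the scatter), since the place differs. Compound 4 is estimated at 700 nM, between 300 nM and 2500 nM.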

Compound 4, half-maximal inhibitory concentration: 2700 nM
For compound 4 the middle estimate is 3.9-fold (0.59 log units) below the measured one; the whole stated range lies below it.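

In this assay the methoxy in place of hydrogen on an aromatic carbon gave a 2.5-fold higher number from compound 3 to compound 4 (0.39 log units; beyond the scatter) and so ran the opposite way on this core. The change therefore does not carry from one core to the other in this series as a fixed step, and the two pairs set side by side differ: the same change on two cores in this assay, a 5.1-fold lower number (0.71 log units; beyond the scatter) from compound 1 to compound 2 and a 2.5-fold higher number (0.39 log units; beyond the scatter) from compound 3 to compound 4, 13-fold (1.10 log units) apart, beyond the scatter of two such steps. What this does not show is the reason, since the two steps differ both in the core and in the place of the methoxy, which in compound 4 sits meta to a large group and meta to a methoxy group, so the two cannot be told apart, and two pairs give no rule for other members of the series.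

The compounds shown leave open whether the step would also reverse on the core of compound 1 with the methoxy meta to a large group. They also leave open how an amine, a carboxylic acid or a longer chain in place of the methoxy would behave on either core.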